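The source may report more compounds than this note shows. Statements on the series, on what has been measured and on what is new or still open speak of the compounds shown alone.

Working notes on the series around the shared core of compound 3, `C/C(=N\OC(c1ccc(OCc2ccc3ccccc3n2)cc1)C1CCCC1)C(=O)O`. In a functional assay for inhibition of Polyunsaturated fatty acid 5-lipoxygenase (Homo sapiens) (on this read-out higher numbers stand for weaker inhibition and lower numbers for stronger inhibition), compound 3 gives 16 nM. Compound 1, `CC/C(=N\OC(c1ccc(OCc2ccc3ccccc3n2)cc1)C1CCCCC1)C(=O)O`, gives 30 nM, a number within the scatter of compound 3, and compound 2, `CC(/C=C/C(=O)O)=N\OC(c1ccc(OCc2ccc3ccccc3n2)cc1)C1CCCCC1`, gives 40 nM, a number beyond the scatter of compound 3. Among the measured compounds shown here, the one measured step, a 1.3-fold higher number from compound 1 to compound 2 (0.12 log units; within the scatter), concerns the acid-bearing chain and not the carbon carrying the cyclopentyl, so it bears only loosely on the next change. Compound 4, `C/C(=N\OCc1ccc(OCc2ccc3ccccc3n2)cc1)C(=O)O`, carries hydrogen in place of cyclopentyl on a saturated chain carbon bound to an aromatic carbon and an oxygen. For the measured compounds named here, no measured step removes a ring at this place; compounds 1 and 3 differ there but also in the chain, so their values show no clean effect. A weakening step is expected, a 7.5-fold higher number from compound 3 to compound 4 (0.88 log units; beyond the scatter), giving compound 4 an estimated 120 nM with range 30 nM to 500 nM.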

Compound 4, half-maximal inhibitory concentration: 1400 nM
Beside the measured number, compound 4's estimate is 12-fold (1.07 log units) below it, outside the stated range (above it).
By their numbers in this assay, from the lowest: compounds 3, 1 and 2 (each within the scatter of the next, the first and the last beyond it); then compound 4.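

Hydrogen in place of cyclopentyl on a saturated chain carbon bound to an aromatic carbon and an oxygen is the first change confined to this place, and in this assay it is a large weakening (an 88-fold higher number from compound 3 to compound 4 (1.94 log units; beyond the scatter)). Among the compounds shown here, the size of this step sets it well apart from the one earlier step, in the acid-bearing chain (a 1.3-fold higher number from compound 1 to compound 2 (0.12 log units; within the scatter)). Nothing on hand accounts for the size of the step.

The compounds shown leave open whether methyl or an open isopropyl chain at this place would restore the number of compound 3 (16 nM). They also leave open how phenyl would compare there.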